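Lengthening the Triazole Chain: Ethyl to Butyl

The source may hold more compounds than are shown below. What is called first, only, known or untested is meant among the compounds shown, and "the series" means these compounds.

Measured so far:
Compound 1, `CNc1nc(-c2cn(Cc3cccc(OC)c3)nn2)nc2c1ncn2[C@@H]1O[C@H](CO)[C@@H](O)[C@H]1O`: 957 nM
Compound 2, `CCNC(=O)[C@H]1O[C@@H](n2cnc3c(NC)nc(-n4cc(Cc5ccccc5)nn4)nc32)[C@H](O)[C@@H]1O`: 510 nM
Compound 3, `CCc1cn(-c2nc(NC)c3ncn([C@@H]4O[C@H](CO)[C@@H](O)[C@H]4O)c3n2)nn1`: 2920 nM

All three were tested in an assay on CHO cells for displacement of a labelled ligand from adenosine receptor A1 (Homo sapiens); on this read-out higher numbers stand for weaker inhibition and lower numbers for stronger inhibition. Compound 3 gives the highest number of the three and is the weakest of them; compound 1 gives 957 nM and compound 2 gives 510 nM, both clearly lower.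

Compound 4, `CCCCc1cn(-c2nc(NC)c3ncn([C@@H]4O[C@H](CO)[C@@H](O)[C@H]4O)c3n2)nn1`, differs from compound 3 in one place: ethyl in place of hydrogen on a saturated chain carbon, two bonds along the chain from an aromatic carbon. Among the compounds with values here, no measured pair differs in exactly this way, so the step size must be judged from the whole set. Compounds 1 and 2, whose triazoles carry a different group than compound 3, give lower numbers. A modest move toward lower numbers is therefore expected, a 1.9-fold lower number from compound 3 to compound 4 (0.29 log units; within the scatter), perhaps just beyond the scatter. Compound 4 is estimated at 1500 nM, within a range from 500 nM to 4500 nM.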

Compound 4, inhibition constant: 848 nM
Estimate against measurement, compound 4: 1.8-fold (0.25 log units) above; the range from low to high includes it.
By their numbers in this assay, from the lowest: compounds 2, 4 and 1 (each within the scatter of the next); then compound 3.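

Going from 4-ethyl-1H-1,2,3-triazol-1-yl to 4-butyl-1H-1,2,3-triazol-1-yl gives the first direct reading of a change at this position: in this assay it produces a 3.4-fold lower number from compound 3 to compound 4 (0.54 log units; beyond the scatter). So adding ethyl to this saturated chain carbon moves the result toward stronger inhibition. This step lies beyond the usual scatter of repeated measurements. No data here show why the longer chain gives this result. A single step cannot show whether the trend continues with a longer chain such as hexyl. It also leaves open how an amine or a carboxylic acid at the chain end would compare.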